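A few compounds are considered here, and "the series" means these few. Any claim that something is new, unique, unknown or untested is made for them only; others in the source may bear on it.

Measured compounds:

- Compound 1, `CNCCN(Cc1ccc(OC)cc1)c1ccccn1`, gives 6.61 nM in a functional assay on ileum for antagonist activity at histamine H1 receptor (Cavia porcellus), read by radioligand binding and fluorescence; on this read-out lower numbers stand for tighter binding and higher numbers for weaker binding.
- Compound 2, `COc1ccc(CN(CCN(C)CCN)c2ccccn2)cc1`, gives 13.2 nM in this assay.
- Compound 3, `COc1ccc(CN(CCN(C)CCCCN)c2ccccn2)cc1`, gives 22.4 nM in this assay.

Compound 3 stands highest of the three numbers: its gap to compound 2 lies within the scatter, while its gap to compound 1 lies beyond it. Compound 4, `COc1ccc(CN(CCN(C)CCCCCCCCN)c2ccccn2)cc1`, is not yet measured. It differs from compound 3 by 4-aminobutyl in place of amino on a saturated chain carbon, four bonds along the chain from an amine nitrogen.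

Among the measured compounds shown here, three measured steps bear on this. The step of a 2.0-fold higher number from compound 1 to compound 2 (0.30 log units; within the scatter) and the step of a 3.4-fold higher number from compound 1 to compound 3 (0.53 log units; beyond the scatter) show that a longer aminoalkyl chain on the amine nitrogen is tolerated with a small rise in the number. The step of a 1.7-fold higher number from compound 2 to compound 3 (0.23 log units; within the scatter), the closest analogue of the present change since it also lengthens the chain by a few carbons, lies within the scatter. Lengthening the chain further, as in compound 4, is therefore expected to give at most a modest further rise in this assay, and possibly none beyond the scatter. The step of a 1.8-fold higher number from compound 3 to compound 4 (0.25 log units; within the scatter) is the expected outcome. Compound 4 is estimated at 40 nM, with a range from 15 nM to 120 nM.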

Compound 4, dissociation constant: 9.77 nM
For compound 4 the middle estimate is 4.1-fold (0.61 log units) above the measured one; the whole stated range lies above it.
By their numbers in this assay, from the lowest: compounds 1, 4, 2 and 3 (each within the scatter of the next, the first and the last beyond it).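

In this assay, lengthening the chain on the amine nitrogen does not keep raising the number: going from the 4-aminobutyl chain to the 8-aminooctyl chain gives a reversal (a 2.3-fold lower number from compound 3 to compound 4 (0.36 log units; beyond the scatter)), against the upward direction of the shorter chains. The other two comparisons (a 1.4-fold lower number from compound 2 to compound 4 (0.13 log units; within the scatter)) and (a 1.5-fold higher number from compound 1 to compound 4 (0.17 log units; within the scatter)) both lie within the scatter, so the 8-aminooctyl chain in place of hydrogen on the amine nitrogen is tolerated, and among the chains shown only compound 3 stands apart from compound 1, which makes it the exception rather than the start of a trend. Nothing on hand accounts for this turn in the numbers.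

Going by these compounds, whether the number stays flat, falls or rises again remains open for chains of intermediate length, such as 6-aminohexyl on the amine nitrogen, and for chains longer than 8-aminooctyl. All the chains shown end in an amino group, so a plain octyl chain, or an octyl chain ending in a hydroxyl group or a carboxylic acid, would be needed to separate the part played by the chain from that of its terminal amine.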